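Shrimp toxicity of a sulfonylurea chalcone: moving the halogen

The source may report more compounds than this note shows. Statements on the series, on what has been measured and on what is new or still open speak of the compounds shown alone.

Measured compounds:
- compound 1, `Cc1ccc(S(=O)(=O)NC(=O)Nc2ccccc2C(=O)/C=C/c2ccccc2O)cc1`: 32.3 ug/mL
- compound 2, `Cc1ccc(S(=O)(=O)NC(=O)Nc2ccccc2C(=O)/C=C/c2ccc(F)cc2)cc1`: 3.96 ug/mL
- compound 3, `Cc1ccc(S(=O)(=O)NC(=O)Nc2ccccc2C(=O)/C=C/c2ccccc2Cl)cc1`: 12.8 ug/mL

These three compounds share one core and differ only in the phenyl ring at the end of the double-bonded chain. In an ADME assay on the whole organism for cytotoxicity, with Artemia salina as the target, with a stated time of 24 h (a lower number here means that less compound is needed, a higher number that more compound is needed for the effect), compound 3 stands second highest of the three numbers; its nearest neighbour is compound 1, which needs more, and the furthest is compound 2, which needs less.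

Compound 4, `Cc1ccc(S(=O)(=O)NC(=O)Nc2ccccc2C(=O)/C=C/c2cccc(Br)c2)cc1`, has not yet been measured. Its change from compound 3 is 3-bromophenyl in place of 2-chlorophenyl on a double-bonded chain carbon bound to a double-bonded chain carbon. Among the measured compounds shown here, no measured step swaps one halogen for another at a new position while keeping the rest of the ring bare, so no step bears directly on it. The closest guide is a 3.2-fold higher number from compound 2 to compound 3 (0.51 log units; beyond the scatter), where one halogenated phenyl gave way to another and the number moved modestly. Both halogen-bearing compounds, compound 2 and compound 3, gave lower numbers than the hydroxy-bearing compound 1, as seen in an 8.2-fold lower number from compound 1 to compound 2 (0.91 log units; beyond the scatter) and a 2.5-fold lower number from compound 1 to compound 3 (0.40 log units; beyond the scatter).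

A modest step downward or none beyond the scatter is therefore expected, a 1.6-fold lower number from compound 3 to compound 4 (0.20 log units; within the scatter). Compound 4 is estimated to give 8 ug/mL in this assay, within a range from 3 ug/mL to 20 ug/mL.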

Compound 4, concentration for half-maximal effect: 4.02 ug/mL
The estimate for compound 4 lay 2.0-fold (0.30 log units) above the measured number; low and high end bracket the measured number.
By their numbers in this assay, from the lowest: compounds 2 and 4 (each within the scatter of the next); then compound 3; then compound 1.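

In this assay, 3-bromophenyl in place of 2-chlorophenyl gives a 3.2-fold lower number from compound 3 to compound 4 (0.50 log units; beyond the scatter), so the number at this end of the chain still moves when one halogen-bearing phenyl replaces another. Halogen-bearing phenyl groups do not always differ, however: 3-bromophenyl in place of 4-fluorophenyl gives a 1.0-fold higher number from compound 2 to compound 4 (0.01 log units; within the scatter), while 3-bromophenyl in place of 2-hydroxyphenyl gives an 8.0-fold lower number from compound 1 to compound 4 (0.90 log units; beyond the scatter). No measurement at hand explains why the numbers fall as they do.

The halogen and its place on the ring change together in every step between halogen-bearing compounds here, so the effect of one cannot be told apart from the effect of the other. A phenyl ring carrying an amine or a carboxylic acid does not appear among the compounds shown, so how such a group would read at this position remains open.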